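The compounds below may be only part of what the source reports. "The series", "measured", "known", "first", "only" and "open" are said of these compounds alone.

Measured so far:
compound 1 `COc1ccc(C2=NN(C3=NC(=O)/C(=C4\C(=O)Nc5ccc(Br)cc54)S3)C(c3ccc(OC)cc3)C2)cc1` — 240 nM
compound 2 `COc1ccc(C2=NN(C3=NC(=O)/C(=C4\C(=O)Nc5ccccc54)S3)C(c3ccc(Cl)cc3)C2)cc1` — 100000 nM

In a functional assay on cells (Cancer cell lines, Homo sapiens) for cytotoxicity, read by sulforhodamine B assay, with a stated time of 48 h (on this read-out higher numbers stand for weaker inhibition of growth and lower numbers for stronger inhibition of growth), compound 2 gives the higher of the two numbers, and compound 1 gives a number far below it, a gap well beyond the scatter. Compound 3 `COc1ccc(C2=NN(C3=NC(=O)/C(=C4\C(=O)Nc5ccc(Br)cc54)S3)C(c3ccc(Cl)cc3)C2)cc1` is built from compound 2 by bromo in place of hydrogen on an aromatic carbon, on the ring of the fused two-ring system. Among the measured compounds shown here, with no single-change step measured, the size of the move is uncertain; since compound 1 carries the bromo and gives 240 nM, a move toward lower numbers, beyond the scatter, is expected. Compound 3 is estimated at 3000 nM, within 300 nM to 50000 nM, which means an expected step of a 33-fold lower number from compound 2 to compound 3 (1.52 log units; beyond the scatter).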

Compound 3, concentration for 50% growth inhibition: 190 nM
Compound 3: the middle estimate sits 16-fold (1.20 log units) above what was measured, outside the stated range (below it).
By their numbers in this assay, from the lowest: compounds 3 and 1 (each within the scatter of the next); then compound 2.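

In this assay, among the compounds shown here, bromo in place of hydrogen on the fused two-ring system, as the only change, gives a 530-fold lower number from compound 2 to compound 3 (2.72 log units; beyond the scatter), so this one position carries a large share of the gap seen between the earlier compounds. With bromo in place, chloro in place of methoxy on an aromatic carbon gives a 1.3-fold lower number from compound 1 to compound 3 (0.10 log units; within the scatter), so this assay does not separate those two groups. Nothing measured here explains the size of the bromo step. Going by these compounds, whether the bromo step is as large with methoxy in place of chloro remains open. Also open, on these data alone, is how fluoro, an amine or a carboxylic acid would compare with bromo at this position.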